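Epimer at the ring stereocentre of compound 2

The source may hold more compounds than are shown below. What is called first, only, known or untested is meant among the compounds shown, and "the series" means these compounds.

Measured so far:
compound 1, `CCC(CC)C(/C=C1\OC(=O)NC1=O)c1ccc(-c2ccc3cccc(F)c3c2)[nH]c1=O`: 13 nM
compound 2, `CC(C)[C@H](C[C@H]1OC(=O)NC1=O)c1ccc(-c2ccc3cccc(F)c3c2)[nH]c1=O`: 6 nM
compound 3, `CC(C)C(c1ccc(-c2ccc3cccc(F)c3c2)[nH]c1=O)C1C(=O)NC(=O)N1C`: 46 nM

In an assay on membranes from Chem-1 cells for displacement of a labelled ligand from prostaglandin E2 receptor EP3 subtype (Homo sapiens), read by scintillation counting, with a stated time of 2 h (a higher number here means a weaker inhibitor, a lower number a stronger inhibitor), compound 2 gives 6 nM, the lowest of the three numbers. Its nearest neighbour, compound 1, gives 13 nM, a gap beyond the scatter, and the furthest, compound 3, gives 46 nM, also beyond the scatter; on these numbers compound 2 is the strongest inhibitor of the three.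

The next compound, compound 4, `CC(C)[C@H](C[C@@H]1OC(=O)NC1=O)c1ccc(-c2ccc3cccc(F)c3c2)[nH]c1=O`, is the stereoisomer of compound 2: the two compounds have the same atoms and bonds and differ only in configuration as drawn: 1 of 2 stereo elements differ; a stereocentre at a saturated ring carbon is drawn R in compound 2 and S in compound 4. Nothing leaves and nothing enters; the two compounds have the same atoms and bonds and differ only in configuration as drawn, at a stereocentre on a saturated ring carbon.

Going by the values given here, no measured pair shows what inverting this stereocentre does. In this assay the step from compound 2 to compound 4 is expected to go toward a higher number, a modest weakening, as the other configuration at that ring carbon is estimated to be the less favourable one, a 3.3-fold higher number from compound 2 to compound 4 (0.52 log units; beyond the scatter). For compound 4 the expected value is therefore 20 nM, with a range from 5 nM to 80 nM.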

Compound 4, inhibition constant: 8 nM
The estimate for compound 4 lay 2.5-fold (0.40 log units) above the measured number; low and high end bracket the measured number.
By their numbers in this assay, from the lowest: compounds 2, 4 and 1 (each within the scatter of the next, the first and the last beyond it); then compound 3.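

In this assay, inverting the stereocentre at the saturated ring carbon gives a 1.3-fold higher number from compound 2 to compound 4 (0.12 log units; within the scatter), so this pair shows no difference between the two drawn configurations at that carbon that can be told from the scatter. The earlier compounds shown here could not show this, as compound 1, compound 2 and compound 3 differ from one another in more than one place and no step could be read among them. The new pair isolates the stereocentre, and the comparison rests on a single point: the fact that compounds 2 and 4 differ only in the configuration as drawn.

The compounds shown leave open whether the second stereocentre, drawn alike in compound 2 and compound 4, can be inverted with as small a step in this assay, since no pair here varies it on its own. They also leave open whether the two configurations at the ring carbon would remain within the scatter of each other with another group on that carbon, such as a methyl group or a carboxylic acid, or with a longer chain in place of the isopropyl group.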